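Removing a tert-butoxycarbonyl group: effect on nitroxide precursors

A few compounds are considered here, and "the series" means these few. Any claim that something is new, unique, unknown or untested is made for them only; others in the source may bear on it.

Measured compounds:
compound 1 `CC1(C)N(O)C(c2ccc(OCC(=O)NCCCC[C@H](N)C(=O)O)cc2)=[N+]([O-])C1(C)C` gives 90600 nM
compound 2 `CC(C)(C)OC(=O)N[C@@H](CCCCNC(=O)COc1ccc(C2=[N+]([O-])C(C)(C)C(C)(C)N2O)cc1)C(=O)O` gives 89900 nM
compound 3 `CC(C)(C)OC(=O)N[C@@H](CCC(=O)NCCOc1ccc(C2=[N+]([O-])C(C)(C)C(C)(C)N2O)cc1)C(=O)O` gives 42700 nM

In a functional assay on PC-12 cells (Rattus norvegicus) for inhibition, read by MTT assay (a lower number here means that less compound is needed, a higher number that more compound is needed for the effect), compound 3 gives the lowest number of the three, and compound 2 is its nearest neighbour. How the core of compound 3 differs from that of compound 2 is not broken down here. Compound 4 `CC1(C)N(O)C(c2ccc(OCCNC(=O)CC[C@H](N)C(=O)O)cc2)=[N+]([O-])C1(C)C` is not yet measured; it differs from compound 3 by hydrogen in place of tert-butoxycarbonyl on an amine nitrogen. The same change already appears once among the measured compounds, from compound 2 to compound 1 (hydrogen in place of tert-butoxycarbonyl on an amine nitrogen), and there it made a 1.0-fold higher number from compound 2 to compound 1 (0.00 log units; within the scatter). Resting on that earlier step, the step from compound 3 to compound 4 is expected to be small, about a 1.0-fold lower number from compound 3 to compound 4 (0.01 log units; within the scatter). Compound 4 is therefore estimated at 42000 nM, most likely between 20000 nM and 90000 nM.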

Compound 4, half-maximal effective concentration: 41800 nM
Beside the measured number, compound 4's estimate is 1.0-fold (0.00 log units) above it; the measured number falls inside the stated range.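

In this assay, swapping tert-butoxycarbonyl for hydrogen on the amine nitrogen gives a 1.0-fold lower number from compound 3 to compound 4 (0.01 log units; within the scatter). The same swap on a second core gave a matching result, so here it carries over from one core to the other: the same change on two cores in this assay, a 1.0-fold higher number (0.00 log units; within the scatter) from compound 2 to compound 1 and a 1.0-fold lower number (0.01 log units; within the scatter) from compound 3 to compound 4, 1.0-fold (0.01 log units) apart, within the scatter of two such steps This shows that the group can be present or absent on these two cores without a difference beyond the scatter in this one cell assay, but it does not show that the same would hold on other cores or in other assays.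

The compounds shown leave open whether a different group on that nitrogen, such as acetyl, would also leave the number in place. They also leave open what a methyl ester in place of the carboxylic acid would do.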